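Changing the group on the amine nitrogen of compound 3

This account rests on a few compounds, and the source may have more. Where it says the series, first, only, none or still open, it means among the compounds named here.

Compound 3 `COC(=O)CNCCCOc1ccc2cc(NC(=O)c3ccc(O)c(CC=C(C)C)c3)c(=O)oc2c1C` is set against compound 2 `CC(C)=CCc1cc(C(=O)Nc2cc3ccc(OCCCN(C(C)C)C(C)C)c(C)c3oc2=O)ccc1O` and compound 1 `CCCN(CCC)CCCOc1ccc2cc(NC(=O)c3ccc(O)c(CC=C(C)C)c3)c(=O)oc2c1C`. In a functional assay on MCF7 cells (Homo sapiens) for antiproliferative activity (a higher number here means a weaker inhibitor, a lower number a stronger inhibitor), compound 3 gives 2820 nM, the highest of the two numbers shown. In this assay compound 2 gives 1310 nM. For compound 1, this assay reports only a limit, > 50000 nM. Compound 4 `CC(C)=CCc1cc(C(=O)Nc2cc3ccc(OCCCN[C@@H]4C[C@H]5CC[C@@H]4C5)c(C)c3oc2=O)ccc1O` differs from compound 3 by a group of 7 heavy atoms (7 carbon; 2 five-membered non-aromatic rings of carbon only) in place of a group of 5 heavy atoms (3 carbon, 2 oxygen; no ring), on an amine nitrogen. All three measured steps alter the same nitrogen. Because an at least 38-fold lower number from compound 1 to compound 2 (1.58 log units; beyond the scatter) and an at least 17-fold lower number from compound 1 to compound 3 (1.24 log units; beyond the scatter) were large, while a 2.2-fold higher number from compound 2 to compound 3 (0.33 log units; beyond the scatter) was modest, a moderate step toward a lower number is expected here, landing between compound 2 and compound 3. Compound 4 is therefore estimated at 1600 nM, within 500 nM to 5000 nM, which is expected to mean a 1.8-fold lower number from compound 3 to compound 4 (0.25 log units; within the scatter).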

Compound 4, half-maximal inhibitory concentration: 1030 nM
Compound 4: middle estimate off by 1.6-fold (0.19 log units), on the high side, and the stated range covers the measured number.
By their numbers in this assay, from the lowest: compounds 4 and 2 (each within the scatter of the next); then compound 3. At a limit, above all of these: compound 1.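

The carbon-only group with two five-membered rings on the amine nitrogen gives a 2.7-fold lower number from compound 3 to compound 4 (0.44 log units; beyond the scatter), so the (methoxycarbonyl)methyl group can be exchanged for a ring-bearing group without loss. Against the diisopropylamino compound, the result is a 1.3-fold lower number from compound 2 to compound 4 (0.10 log units; within the scatter), so these two groups cannot be told apart here. Compound 1 is known only as a limit, so an at least 48-fold lower number from compound 1 to compound 4 (1.68 log units; beyond the scatter) gives a minimum size, and dipropylamino still stands apart from the other groups on this nitrogen: the limit of > 50000 nM in this assay, at which 1 of the 4 values shown sits.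

From the compounds shown here alone, whether a single-ring cyclohexyl group or a free carboxylic acid in place of the methyl ester would give similar numbers remains open. Also open, going by these compounds, is whether the three defined stereocentres of the new group matter.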